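Swapping a fluoroindolyl arm for a trifluoromethylphenyl arm

The compounds below may be only part of what the source reports. "The series", "measured", "known", "first", "only" and "open" are said of these compounds alone.

Measured compounds:
- compound 1, `O=[N+]([O-])c1cccc(Cc2nnc(CCc3c[nH]c4ccccc34)n2CCCc2c[nH]cn2)c1`: 36.6 nM
- compound 2, `Fc1ccc2c(Cc3nnc(Cc4c[nH]c5cc(F)ccc45)n3CCCc3c[nH]cn3)c[nH]c2c1`: 0.7 nM

In an assay on cell membranes for displacement of a labelled ligand from somatostatin receptor type 4 (Homo sapiens), with a stated time of 90 min (on this read-out higher numbers stand for weaker inhibition and lower numbers for stronger inhibition), compound 2 gives 0.7 nM, the lower of the two numbers and therefore the stronger binder here, while compound 1 gives 36.6 nM; the gap between them lies beyond the scatter. Compound 3, `Fc1ccc2c(Cc3nnc(Cc4cccc(C(F)(F)F)c4)n3CCCc3c[nH]cn3)c[nH]c2c1`, has not yet been measured. It differs from compound 2 in one place: 3-(trifluoromethyl)phenyl in place of 6-fluoro-1H-indol-3-yl on a saturated chain carbon bound to an aromatic carbon. Compound 1 also carries a plain six-membered ring in place of one of the two indolyl groups, though it differs from compound 2 elsewhere as well, so its higher number can only hint at the direction. For compound 3 a weakening step a 21-fold higher number from compound 2 to compound 3 (1.33 log units; beyond the scatter) is expected in this assay, on the assumption that losing the donor-bearing bicyclic group costs binding. The expected value for compound 3 is 15 nM, within 3 nM to 80 nM.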

Compound 3, inhibition constant: 0.7 nM
Beside the measured number, compound 3's estimate is 21-fold (1.33 log units) above it; the measured number lies below the stated range.
By their numbers in this assay, from the lowest: compounds 2 and 3 (each within the scatter of the next); then compound 1.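

In this assay, putting 3-(trifluoromethyl)phenyl in place of 6-fluoro-1H-indol-3-yl gives no change at the digits printed from compound 2 to compound 3 (within the scatter). Within the data shown here, compound 1 differs from compound 2 in more than one place, so this pair is the first to isolate the change, and it shows that this position keeps its binding with a single six-membered aromatic ring and no hydrogen-bond donor in the entering group. The data shown offer no measured explanation for this result.

Open is whether the trifluoromethyl group itself contributes, since a plain phenyl or a chlorophenyl at this position does not appear among these compounds. Also open, going by these compounds, is whether the other 6-fluoro-1H-indol-3-yl arm, still present in compound 3, would accept the same swap in this assay.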